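The source may hold more compounds than are shown below. What is called first, only, known or untested is meant among the compounds shown, and "the series" means these compounds.

Compound 1 `c1ccc(-c2cc(-c3ccsc3)cc(-c3ccccn3)n2)nc1`: 0.62 ug/mL
Compound 2 `c1ccc(-c2cc(-c3ccccn3)nc(-c3ccccn3)c2)cc1`: 0.56 ug/mL

In a functional assay on A549 cells (Homo sapiens) for antiproliferative activity (a higher number here means a weaker inhibitor of growth, a lower number a stronger inhibitor of growth), compound 2 stands together with compound 1, since a 1.1-fold lower number from compound 1 to compound 2 (0.04 log units; within the scatter) is within the scatter. Compound 3 `c1ccc(-c2cc(-c3ccco3)cc(-c3ccccn3)n2)nc1` differs from compound 2 in one place: furan-2-yl in place of phenyl on an aromatic carbon. Going by the values given here, one measured step bears on this: a 1.1-fold lower number from compound 1 to compound 2 (0.04 log units; within the scatter) replaced a five-membered aromatic ring with phenyl at this carbon and left the number essentially unchanged. Returning to a five-membered aromatic ring is therefore expected to move the number little, and a 1.1-fold higher number from compound 2 to compound 3 (0.03 log units; within the scatter) is expected to stay within the scatter. Compound 3 is estimated at 0.6 ug/mL, with a range from 0.3 ug/mL to 1.2 ug/mL.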

Compound 3, concentration for 50% growth inhibition: 0.22 ug/mL
Compound 3: middle estimate off by 2.7-fold (0.44 log units), on the high side; measured number outside the range, below it.
By their numbers in this assay, from the lowest: compound 3; then compounds 2 and 1 (each within the scatter of the next).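

In this assay, this carbon, opposite the ring nitrogen, does not treat all aromatic rings alike: furan-2-yl gives a 2.5-fold lower number from compound 2 to compound 3 (0.41 log units; beyond the scatter) and a 2.8-fold lower number from compound 1 to compound 3 (0.45 log units; beyond the scatter). The earlier match between phenyl and thiophen-3-yl therefore does not extend to every aromatic ring here, and being five-membered does not by itself set the number. Nothing available explains the lower number for furan-2-yl.

Still open, as far as these compounds go, is whether the ring oxygen or the point of attachment matters, as furan-2-yl and thiophen-3-yl differ in both. Also open, from the compounds shown here alone, is how furan-3-yl, or a non-aromatic group such as an amine, would compare at this carbon.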